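Three Limits and One Untested Analogue

This account rests on a few compounds, and the source may have more. Where it says the series, first, only, none or still open, it means among the compounds named here.

compound 1 `CN(C)c1ccc(NC(=O)c2csc(Cc3c(Cl)cccc3Cl)n2)cc1` — > 4000 nM
compound 2 `O=C(Nc1cccc(Br)c1)c1csc(Cc2c(Cl)cccc2Cl)n1` — > 4000 nM
compound 3 `O=C(Nc1ccc(C(F)(F)F)cc1)c1csc(-c2c(Cl)cccc2Cl)n1` — > 4000 nM

In an assay on CHO cells, read by calcium flux (a lower number here means a stronger inhibitor, a higher number a weaker inhibitor), compound 1 gives > 4000 nM, which is a limit of the assay rather than a number. Compound 2 gives > 4000 nM, again a limit. Compound 3 gives > 4000 nM, also a limit. Within the data shown here, every value shown therefore sits at the same point, (the limit of > 4000 nM in this assay, at which 3 of the 3 values shown sit), and no step between measured compounds can be reckoned. Compound 3 stands where compound 1 and compound 2 stand: without a number of its own, only the limit.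

Compound 4 `O=C(Nc1ccc(C(F)(F)F)cc1)c1csc(Nc2ccccc2Cl)n1` differs from compound 3 by (2-chlorophenyl)amino in place of 2,6-dichlorophenyl on an aromatic carbon. Nothing measured bears on this change, so the expectation rests on the limits alone. The step from compound 3 to compound 4 in this assay is expected to be a step that the limit leaves unreadable from compound 3 to compound 4, that is, no movement beyond the scatter in either direction. Compound 4 is estimated to give 5000 nM in this assay, within 800 nM to 30000 nM, with a real chance that only a limit is returned once more.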

Compound 4, half-maximal inhibitory concentration: 1750 nM
Estimate against measurement, compound 4: 2.9-fold (0.46 log units) above; measured number inside the range.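

Among these compounds, putting (2-chlorophenyl)amino in place of 2,6-dichlorophenyl on this aromatic carbon, next to the ring nitrogen and next to the ring sulfur, gives in this assay an at least 2.2-fold lower number from compound 3 to compound 4 (0.35 log units; beyond the scatter), and compound 4 is the first compound here with a number rather than a limit. Among the compounds shown here, this position therefore tolerates change and can affect the reading, which the earlier compounds could not show. The full size of the step stays unknown, and only its lower bound can be read: the limit of > 4000 nM in this assay, at which 3 of the 4 values shown sit.

The change swaps the ring's link and its chlorine count together, so the compounds shown do not separate the contribution of the entering nitrogen from that of the departing chlorine. They also leave open how a piperidine or a (2-methoxyphenyl)amino group would read at this position.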